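The source may report more compounds than this note shows. Statements on the series, on what has been measured and on what is new or still open speak of the compounds shown alone.

Of the compounds shown here, three from one series have been tested in a functional assay on HeLa cells (Homo sapiens) for inhibition, read by CCK-8 assay, with a stated time of 48 h; on this read-out lower numbers stand for stronger inhibition and higher numbers for weaker inhibition. Compound 1 `O=C(NCCNS(=O)(=O)c1ccc(-c2ccccc2O[C@H]2CC[C@@H](O)CC2)s1)Nc1ccc([N+](=O)[O-])cc1` carries a (4-nitrophenyl)carbamoyl group on an amine nitrogen whose other neighbours are a saturated chain carbon. In this assay compound 1 reaches only the limit of > 20000 nM, which is a boundary of the measurement and not a number. Compound 2 `O=[N+]([O-])c1ccc(NC(=S)NCCNS(=O)(=O)c2ccc(-c3ccccc3O[C@H]3CC[C@@H](O)CC3)s2)cc1` differs from compound 1 by a group of 12 heavy atoms (7 carbon, 2 nitrogen, 2 oxygen, 1 sulfur; one six-membered aromatic ring of carbon only) in place of a group of 12 heavy atoms (7 carbon, 2 nitrogen, 3 oxygen; one six-membered aromatic ring of carbon only), on an amine nitrogen. In this assay compound 2 likewise stops at the limit of > 20000 nM. The step that the two limits leave unreadable from compound 1 to compound 2 cannot be read, because both results sit at the limit of > 20000 nM in this assay, at which 3 of the 3 values shown sit.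

Compound 3 `Cc1ccc(-c2ccsc2S(=O)(=O)NCCNC(=O)Nc2ccc([N+](=O)[O-])cc2)c(Oc2ccc(O)c(O)c2)c1` is built on another core; the difference between the two cores is not broken down here. In this assay compound 3 also gives only the limit of > 20000 nM. Compound 4 `Cc1ccc(-c2ccsc2S(=O)(=O)NCCNC(=S)Nc2ccc([N+](=O)[O-])cc2)c(Oc2ccc(O)c(O)c2)c1` has not yet been measured and differs from compound 3 by a group of 12 heavy atoms (7 carbon, 2 nitrogen, 2 oxygen, 1 sulfur; one six-membered aromatic ring of carbon only) in place of a group of 12 heavy atoms (7 carbon, 2 nitrogen, 3 oxygen; one six-membered aromatic ring of carbon only), on an amine nitrogen, the same change as that made from compound 1 to compound 2, at the same place.

The expectation for compound 4 rests on compound 3, which in this assay sits at > 20000 nM, and on the earlier swap, whose step that the two limits leave unreadable from compound 1 to compound 2 could not be read because both partners lie at the limit of > 20000 nM in this assay, at which 3 of the 3 values shown sit. The estimated step that the limit leaves unreadable from compound 3 to compound 4 is therefore expected to be small. Compound 4 is expected to come out near 30000 nM, most probably reported again only as a limit, within an estimated range from 10000 nM to 100000 nM.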

Compound 4, half-maximal inhibitory concentration: 6800 nM
Compound 4: middle estimate off by 4.4-fold (0.64 log units), on the high side; the measured number lies below the stated range.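

In this assay, going by these compounds, replacing the (4-nitrophenyl)carbamoyl group on the amine nitrogen with the sulfur-containing group gives an at least 2.9-fold lower number from compound 3 to compound 4 (0.46 log units; beyond the scatter), so on this core the change lowers the number beyond the scatter, and the true size of the step remains unknown, as the starting point is only a limit. The same change on the core of compound 1, the step to compound 2, cannot be read, because both partners stop at a boundary of the measurement and not at a number: the limit of > 20000 nM in this assay, at which 3 of the 4 values shown sit. The change therefore turned a limit into a measured number on one core only, while compound 2 remains at a limit; this pair neither confirms nor rules out that the change carries over, and one readable step cannot establish a rule for the series.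

On these data alone, the two cores differ in more than one place, so it stays open which part of the core of compound 3 matters for the lower number seen with compound 4. Every compound shown also keeps the nitro group on its aromatic ring, which leaves open how the same change would behave with an amine or a carboxylic acid in that group's place.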